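Replacing 1-phenylethyl with 3-(dimethylamino)propyl on the shared core

This account rests on a few compounds, and the source may have more. Where it says the series, first, only, none or still open, it means among the compounds named here.

Among the compounds with values here, only one compound in this small series has a number. In a functional assay on MCF7 cells (Homo sapiens) for cytotoxicity, read by MTT assay, with a stated time of 72 h (a higher number here means a weaker inhibitor, a lower number a stronger inhibitor), compound 1 (`N[C@H]1CC[C@H](Nc2c(C(=O)NCc3ccc(F)cc3)nc(N3CCCCS3(=O)=O)c3cccnc23)CC1`) gives 13000 nM. In the same test, compound 2 (`N[C@H]1CC[C@H](Nc2c(C(=O)NCc3ccco3)nc(Br)c3cccnc23)CC1`) stands as "not determined" (no result reported). Compound 3 (`C[C@@H](Nc1c(C(=O)NCc2ccc(F)cc2)nc(Br)c2cccnc12)c1ccccc1`) also has no single number, and its entry reads "not determined" (no result reported). It therefore offers no measured starting point.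

Compound 4 (`CN(C)CCCNc1c(C(=O)NCc2ccc(F)cc2)nc(Br)c2cccnc12`) follows from compound 3 by one structural change: 3-(dimethylamino)propyl in place of 1-phenylethyl on a nitrogen on an aromatic ring. Put simply, 3-(dimethylamino)propyl takes the place of 1-phenylethyl on a nitrogen on an aromatic ring. Within the data shown here, with no measured step to draw on, the size of this change in this assay cannot be read from the data, and no direction is favoured. Among the measured compounds shown here, the only anchor is compound 1 at 13000 nM, and no shift from that region beyond the usual scatter is expected, although the uncertainty is wide. Compound 4 is expected at an estimated 10000 nM, within an estimated range of 2500 nM to 40000 nM.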

Compound 4, half-maximal inhibitory concentration: 7000 nM
Compound 4: middle estimate off by 1.4-fold (0.15 log units), on the high side; measured number inside the range.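

Compound 3 has no single number in this assay, and the change from it to compound 4 therefore cannot be read as a step. No evidence on hand bears on this result. On these data alone, what replacing 1-phenylethyl with 3-(dimethylamino)propyl does to cytotoxicity remains open.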